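The compounds below may be only part of what the source reports. "The series", "measured", "known", "first", "only" and "open" are said of these compounds alone.

Compound 1 `Nc1cccn2cc(Cc3ccccc3)c(=O)nc12` gives 116000 nM
Compound 2 `O=c1nc2ccccn2cc1Cc1ccc(F)cc1` gives 125000 nM

In a functional assay on SK-N-SH cells (Homo sapiens) for cytotoxicity, read by MTT assay, with a stated time of 24 h (on this read-out higher numbers stand for weaker inhibition and lower numbers for stronger inhibition), compound 2 stands at 125000 nM and lies within the usual scatter of compound 1 with its 116000 nM on the same read-out. Compound 3 `O=c1nc2ccccn2cc1Cc1ccccc1` differs from compound 2 in one place: hydrogen in place of fluoro on an aromatic carbon with hydrogen in place of fluoro on an aromatic carbon. Among the compounds with values here, no measured step shows this change on its own, though compound 1 at 116000 nM also carries no fluoro. In this assay the estimated step of a 1.0-fold lower number from compound 2 to compound 3 (0.02 log units; within the scatter) is expected to stay within the scatter. Compound 3 is estimated at 120000 nM with an expected range from 70000 nM to 220000 nM on this read-out.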

Compound 3, half-maximal inhibitory concentration: 95400 nM
Compound 3: the middle estimate sits 1.3-fold (0.10 log units) above what was measured, and the stated range covers the measured number.
By their numbers in this assay, from the lowest: compounds 3, 1 and 2 (each within the scatter of the next).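

In this assay hydrogen in place of fluoro, para to a large group, gives a 1.3-fold lower number from compound 2 to compound 3 (0.12 log units; within the scatter) and so stays within the scatter at this position. Hydrogen in place of amino on an aromatic carbon of the shared core gives a 1.2-fold lower number from compound 1 to compound 3 (0.08 log units; within the scatter) and likewise stays within the scatter, so neither group separates itself from hydrogen on this read-out. Nothing measured here bears on why these compounds read alike.

Going by these compounds, whether a carboxylic acid or a methoxy group at the para place would move the number remains open. So does whether a longer chain in place of the amino group would do so.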